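Heptyl in place of methoxyphenyl on the shared core

This account rests on a few compounds, and the source may have more. Where it says the series, first, only, none or still open, it means among the compounds named here.

Compound 2 `COc1ccc(C(c2c[nH]c3ccc(Br)cc23)c2c[nH]c3ccc(Br)cc23)cc1` gives 10000 nM in a functional assay on A549 cells (Homo sapiens) for inhibition, read by MTT assay, with a stated time of 48 h (a higher number here means a weaker inhibitor, a lower number a stronger inhibitor), the second highest of the three numbers shown. Compound 1 `Brc1ccc2[nH]cc(C(c3ccccc3)c3c[nH]c4ccc(Br)cc34)c2c1` gives 7500 nM in this assay, and the step of a 1.3-fold higher number from compound 1 to compound 2 (0.12 log units; within the scatter) lies within the scatter. Compound 3 `COc1cccc(C(c2c[nH]c3ccc(Br)cc23)c2c[nH]c3ccc(Br)cc23)c1OC` gives 100000 nM in this assay; the step of a 10-fold higher number from compound 2 to compound 3 (1.00 log units; beyond the scatter) is beyond the scatter, as is a 13-fold higher number from compound 1 to compound 3 (1.12 log units; beyond the scatter). Compound 4 `CCCCCCCC(c1c[nH]c2ccc(Br)cc12)c1c[nH]c2ccc(Br)cc12` carries the change (heptyl in place of 4-methoxyphenyl on a saturated chain carbon bound to two aromatic carbons). Within the data shown here, both measured steps that altered the group on the saturated chain carbon raised the number, but neither put a chain in place of a ring, so no measured step matches this change directly. A modest step toward a higher number is therefore expected: a 1.5-fold higher number from compound 2 to compound 4 (0.18 log units; within the scatter). Compound 4 is estimated at 15000 nM, between 4000 nM and 60000 nM.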

Compound 4, half-maximal inhibitory concentration: 3500 nM
Compound 4: middle estimate off by 4.3-fold (0.63 log units), on the high side, outside the stated range (below it).
By their numbers in this assay, from the lowest: compound 4; then compounds 1 and 2 (each within the scatter of the next); then compound 3.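

In this assay, the saturated chain carbon bound to two aromatic carbons accepts a group with no ring, giving a 2.9-fold lower number from compound 2 to compound 4 (0.46 log units; beyond the scatter), a 2.1-fold lower number from compound 1 to compound 4 (0.33 log units; beyond the scatter) and a 29-fold lower number from compound 3 to compound 4 (1.46 log units; beyond the scatter). No earlier step from compound 1 or compound 2 had lowered the number beyond the scatter, so heptyl is the first group shown to do so at this position. Nothing available explains this result. The compounds shown leave open how a shorter chain such as butyl, a longer chain such as decyl, or a heptyl chain ending in an amine would compare.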